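The source may hold more compounds than are shown below. What is called first, only, known or untested is meant among the compounds shown, and "the series" means these compounds.

Three compounds share one core and differ only at the far end of a chain. Compound 1 `O=C(O)CCC(=O)OCCCCCCSc1ccc([N+](=O)[O-])c2nonc12` carries a hydroxy on the last carbonyl carbon; in an ADME assay on L02 cells (Homo sapiens) for cytotoxicity, read by MTT assay, with a stated time of 72 h (on this read-out lower numbers stand for stronger inhibition and higher numbers for weaker inhibition), compound 1 gives 1890 nM. Compound 2 `O=C(CCC(=O)OCCCCCCSc1ccc([N+](=O)[O-])c2nonc12)Nc1ccccc1Cl` gives 5850 nM, and compound 3 `CN(C)CCNC(=O)CCC(=O)OCCCCCCSc1ccc([N+](=O)[O-])c2nonc12` gives 5980 nM. Replacing the hydroxy gave a 3.1-fold higher number from compound 1 to compound 2 (0.49 log units; beyond the scatter) and a 3.2-fold higher number from compound 1 to compound 3 (0.50 log units; beyond the scatter), while exchanging the group on the amide-type nitrogen gave a 1.0-fold higher number from compound 2 to compound 3 (0.01 log units; within the scatter). Compound 2 therefore stands second highest of the three numbers, within the usual scatter of compound 3 and clearly apart from compound 1.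

Compound 4 `O=C(CCC(=O)OCCCCCCSc1ccc([N+](=O)[O-])c2nonc12)NCCN1CCCC1` has not been measured yet. It differs from compound 2 in one place: 2-(pyrrolidin-1-yl)ethyl in place of 2-chlorophenyl on an amide-type nitrogen. For the measured compounds named here, the single measured step that bears on this is a 1.0-fold higher number from compound 2 to compound 3 (0.01 log units; within the scatter). Compound 3 also carries a 2-(dimethylamino)ethyl on that nitrogen in place of the 2-chlorophenyl, and that exchange moved nothing beyond the scatter. On that basis compound 4 is expected to stay close to compound 2, with an expected step of a 1.0-fold higher number from compound 2 to compound 4 (0.01 log units; within the scatter) in this assay. The estimate for compound 4 is 6000 nM, with a likely range from 2500 nM to 14000 nM.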

Compound 4, half-maximal inhibitory concentration: 6580 nM
Beside the measured number, compound 4's estimate is 1.1-fold (0.04 log units) below it; measured number inside the range.
By their numbers in this assay, from the lowest: compound 1; then compounds 2, 3 and 4 (each within the scatter of the next).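

In this assay, 2-(pyrrolidin-1-yl)ethyl on the amide-type nitrogen gives a 1.1-fold higher number from compound 2 to compound 4 (0.05 log units; within the scatter), so a second replacement for 2-chlorophenyl, this one swapping a six-membered aromatic ring of carbon only for a five-membered non-aromatic ring with 1 hetero atom, also stays within the scatter. Tying the end of the side chain into a ring makes no readable difference either: pyrrolidin-1-yl in place of dimethylamino gives a 1.1-fold higher number from compound 3 to compound 4 (0.04 log units; within the scatter), while the change from hydroxy on the carbonyl carbon gives a 3.5-fold higher number from compound 1 to compound 4 (0.54 log units; beyond the scatter), so compounds 2, 3 and 4 all stand apart from compound 1 but not from one another. No measurement here explains why these three amides sit together or why compound 1 stands apart.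

The compounds shown leave open whether the number would also hold with a morpholin-4-yl group at the end of the ethyl chain, or with a longer chain leading to the amine. They also leave open whether a plain primary amide, with only hydrogens on that nitrogen, would sit with compounds 2, 3 and 4 or with compound 1.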